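Fluoro to cyano on compound 3

The compounds below may be only part of what the source reports. "The series", "measured", "known", "first", "only" and "open" are said of these compounds alone.

Among the compounds with values here, in a functional assay on PC-3 cells (Homo sapiens) for cytotoxicity, read by MTT assay, with a stated time of 72 h (a lower number here means a stronger inhibitor, a higher number a weaker inhibitor), compound 1 (`CNC(=O)c1cc(Oc2ccc(C3=NNC(c4ccccc4)C3)cc2)ccn1`) gives 4520 nM and compound 2 (`CNC(=O)c1cc(Oc2ccc(C3=NNC(c4ccc(F)cc4)C3)cc2)ccn1`) gives 6770 nM on the numbers so far. Fluoro in place of hydrogen on an aromatic carbon accounts for a 1.5-fold higher number from compound 1 to compound 2 (0.18 log units; within the scatter) in this pair. A group of 3 heavy atoms in place of a hydrogen atom on an amine nitrogen in a ring then brings an at least 7.3-fold higher number from compound 2 to compound 3 (0.86 log units; beyond the scatter) and yields compound 3 (`CNC(=O)c1cc(Oc2ccc(C3=NN(C(N)=S)C(c4ccc(F)cc4)C3)cc2)ccn1`).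

Compound 3 reads > 50000 nM in this assay and that is a limit of the assay, not a number.

Compound 4 (`CNC(=O)c1cc(Oc2ccc(C3=NN(C(N)=S)C(c4ccc(C#N)cc4)C3)cc2)ccn1`) differs from it in one place, with cyano in place of fluoro on an aromatic carbon, a change from 4-fluorophenyl to 4-cyanophenyl. Within the data shown here, only one measured step touches that place, namely a 1.5-fold higher number from compound 1 to compound 2 (0.18 log units; within the scatter) and it was seen without the group that compound 3 carries on the ring nitrogen. The other step lies elsewhere and only sets the level from which compound 4 starts. Among the measured compounds shown here, no measured compound carries cyano, and compound 3 offers no exact number to start from. A step beyond the scatter in this assay is therefore not expected.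

The expected result is a number no higher from compound 3 to compound 4 (the limit leaves the size open) and this remains an estimate. For compound 4 the estimated value is 50000 nM with an expected range from 20000 nM to 120000 nM and a report as a limit alone is likely.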

Compound 4, half-maximal inhibitory concentration: > 50000 nM
Compound 4 was reported as a limit; the forecaster's own chance of this, stated with the estimate: 70%; the middle value sits exactly at the limit.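

Compound 4 reads > 50000 nM in this assay, and this is a limit, not a number. Compound 3 also stands only as a limit, so no step can be read between compound 3 and compound 4: the limit of > 50000 nM in this assay, at which 2 of the 4 values shown sit.

The compounds shown leave open what exact number either compound would give, and so what cyano in place of fluoro does here.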